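This account rests on a few compounds, and the source may have more. Where it says the series, first, only, none or still open, it means among the compounds named here.

Compound 1 `O=C1C=C(N2CCC2)C(=O)c2c1nc1n2[C@H]2OC[C@@H](O)[C@H]2OC1`: > 16000 nM
Compound 2 `COc1ccccc1NC1=CC(=O)c2c(nc3n2[C@H]2OC[C@@H](O)[C@H]2OC3)C1=O`: > 4000 nM
Compound 3 `O=C1C(N2CCCC2)=CC(=O)c2c1nc1n2[C@H]2OC[C@@H](O)[C@H]2OC1`: > 16000 nM

All three compounds were tested in a functional assay on ECa-109 cells for inhibition, with ECa-109 cell line (Homo sapiens) as the target, read by sulforhodamine B assay (on this read-out lower numbers stand for stronger inhibition and higher numbers for weaker inhibition), and none has yet given a number. In this assay compound 1 gives > 16000 nM, which is a limit of the assay, and it stands at the limit of > 16000 nM in this assay, at which 2 of the 3 values shown sit.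

Compound 4 `O=C1C=C(Nc2ccc(Br)cc2)C(=O)c2c1nc1n2[C@H]2OC[C@@H](O)[C@H]2OC1` has not yet been measured. It departs from compound 1 as follows: (4-bromophenyl)amino in place of azetidin-1-yl on a double-bonded ring carbon. Thus (4-bromophenyl)amino takes the place of azetidin-1-yl.

Going by the values given here, one measured step bears on this change: a step that the two limits leave unreadable from compound 2 to compound 3. Compound 2, which carries (2-methoxyphenyl)amino at that place, gives > 4000 nM, also a limit. Compound 3 gives > 16000 nM, again a limit. These limits fix no size, so only a tentative expectation is possible, of stronger inhibition in this assay, resting on the lower limit of compound 2 at > 4000 nM.

The expected change is an at least 2.6-fold lower number from compound 1 to compound 4 (0.42 log units; beyond the scatter). For compound 4 the estimated value is 6000 nM, with an expected range from 1500 nM to 20000 nM.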

Compound 4, half-maximal inhibitory concentration: 2850 nM
Estimate against measurement, compound 4: 2.1-fold (0.32 log units) above; measured number inside the range.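

Going by these compounds alone, compound 4 is the only one of the four compounds to give a number rather than a limit in this assay, so this position on a double-bonded ring carbon can carry a group that brings inhibition into the measurable range. Replacing azetidin-1-yl with (4-bromophenyl)amino gives an at least 5.6-fold lower number from compound 1 to compound 4 (0.74 log units; beyond the scatter). The true size of this step may be larger, and it is stated only as a lower bound because compound 1 stays at a limit: the limit of > 16000 nM in this assay, at which 2 of the 4 values shown sit.

The compounds shown leave open whether the bromine, the aromatic ring or the added hydrogen-bond donor accounts for the step. A plain phenylamino group or a (4-chlorophenyl)amino group at this place would begin to separate these parts.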